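A Methoxy for a Methyl on the Amide Chain

A few compounds are considered here, and "the series" means these few. Any claim that something is new, unique, unknown or untested is made for them only; others in the source may bear on it.

Compound 1, `CCC(=O)N(Cc1ccc(OC)c(O)c1)c1cc(OC)c(OC)c(OC)c1`: 61 nM
Compound 2, `C/C=C/C(=O)N(Cc1cc(OC)c(OC)c(OC)c1)c1ccc(OC)c(O)c1`: 8450 nM
Compound 3, `C/C=C/C(=O)N(Cc1ccc(OC)c([N+](=O)[O-])c1)c1cc(OC)c(OC)c(OC)c1`: 670 nM

All three were tested in a functional assay on HCT-116 cells (Homo sapiens) for inhibition, read by MTT assay, with a stated time of 48 h; a lower number here means a stronger inhibitor, a higher number a weaker inhibitor. Compound 1 gives 61 nM, the lowest of the three numbers. Its nearest neighbour is compound 3, which gives 670 nM, and the furthest is compound 2, which gives 8450 nM. Both gaps lie beyond the scatter, so compound 1 is the strongest inhibitor of the measured three in this assay.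

Compound 4, `COCC(=O)N(Cc1ccc(OC)c(O)c1)c1cc(OC)c(OC)c(OC)c1`, has not yet been measured. It differs from compound 1 in a single place: methoxy in place of methyl on a saturated chain carbon bound to a carbonyl carbon. Among the compounds with values here, no pair of measured compounds shows this change on its own, so what can be expected of compound 4 rests on compound 1 alone and on the nature of the change, methoxy in place of methyl on a saturated chain carbon bound to a carbonyl carbon.

The step of a 2.0-fold higher number from compound 1 to compound 4 (0.29 log units; within the scatter) is expected to be small, at most a modest move toward a weaker inhibitor, or none beyond the scatter. Compound 4 is accordingly estimated at 120 nM, within a range from 40 nM to 400 nM.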

Compound 4, half-maximal inhibitory concentration: 230 nM
Beside the measured number, compound 4's estimate is 1.9-fold (0.28 log units) below it; the range from low to high includes it.
By their numbers in this assay, from the lowest: compound 1; then compound 4; then compound 3; then compound 2.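

In this assay, methoxy in place of methyl on a saturated chain carbon bound to a carbonyl carbon gives a 3.8-fold higher number from compound 1 to compound 4 (0.58 log units; beyond the scatter), a modest step beyond the scatter. This shows that the position responds to the change, and that the response runs toward a weaker inhibitor. Nothing measured here explains why the number rises with this change.

The compounds shown leave open how an amine, a carboxylic acid or a longer chain such as ethoxy would read at this position. Within the data shown here, with only this one pair, they also leave open whether the same change would give a step of similar size or direction on another core.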